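The compounds below may be only part of what the source reports. "The series", "measured", "known", "first", "only" and "open" are said of these compounds alone.

Within the data shown here, compound 1 `O=S(=O)(Nc1cc(-c2cnc3[nH]cc(-c4ccncc4)c3c2)cnc1Cl)c1ccccc1F` stands at the lower of the two numbers measured so far: in a functional assay on Pfeiffer cells (Homo sapiens) for inhibition, read by CCK-8 assay (a higher number here means a weaker inhibitor of growth, a lower number a stronger inhibitor of growth), compound 1 gives 290 nM. Compound 2 `O=S(=O)(Nc1cc(-c2cnc3[nH]ncc3c2)cnc1Cl)c1ccccc1` differs from compound 1 in several places at once; in this assay compound 2 gives 1160 nM. Compound 3 `O=S(=O)(Nc1cc(-c2cnc3[nH]cc(-c4ccncc4)c3c2)cnc1Cl)c1ccccc1` is compound 1 with one small change: hydrogen in place of fluoro on an aromatic carbon. Among the measured compounds shown here, with no step between measured compounds of this kind to lean on, the step expected here is a 1.4-fold higher number from compound 1 to compound 3 (0.14 log units; within the scatter), small and likely within the scatter, leaning if anything toward a higher number. Compound 3 is therefore expected to give about 400 nM, in the range 150 nM to 1200 nM.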

Compound 3, concentration for 50% growth inhibition: 100 nM
Beside the measured number, compound 3's estimate is 4.0-fold (0.60 log units) above it; measured number below the stated range.
By their numbers in this assay, from the lowest: compound 3; then compound 1; then compound 2.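

Going from the 2-fluorophenyl to the phenyl group gives a 2.9-fold lower number from compound 1 to compound 3 (0.46 log units; beyond the scatter) in this assay. This single atom on the aromatic ring therefore matters in this series, and here the compound carrying hydrogen, not fluoro, is the stronger inhibitor of growth. Nothing shown accounts for this step. On these data alone, it remains open whether a methyl, a methoxy or a chloro group at this same place would give a number nearer to that of hydrogen or of fluoro. As far as these compounds go, it also remains open whether an amine there would be tolerated.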